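The source may report more compounds than this note shows. Statements on the series, on what has been measured and on what is new or still open speak of the compounds shown alone.

Two compounds carry measured numbers. Compound 1 `O=C(/C=C/c1ccc(Oc2cc(=O)oc3ccccc23)cc1)/C=C/c1cccnc1` in a functional assay on SGC-7901 cells (Homo sapiens) for antiproliferative activity, read by MTT assay, with a stated time of 48 h (on this read-out lower numbers stand for stronger inhibition and higher numbers for weaker inhibition), gives 17400 nM. Compound 2 `COc1cc(OC)c2c(=O)c(OCCCOc3ccccc3/C=C/C(=O)/C=C/c3ccccn3)c(-c3cc(OC)c(OC)c(OC)c3)oc2c1` in this assay gives 1080 nM, the lowest of the two numbers shown; compound 1 sits well above it, and that gap lies beyond the usual scatter of the read-out. Compound 3 `COc1cc(OC)c2c(=O)c(OCCCOc3ccccc3/C=C/C(=O)/C=C/c3scnc3C)c(-c3cc(OC)c(OC)c(OC)c3)oc2c1` has not yet been measured. It differs from compound 2 in one place only: 4-methyl-1,3-thiazol-5-yl in place of pyridin-2-yl on a double-bonded chain carbon bound to a double-bonded chain carbon. For the measured compounds named here, no pair of measured compounds shows this same change, so nothing measured tells how large a step it brings or in which direction. Going by the values given here, the one comparison at hand, compound 1 against compound 2, differs in far more than a single ring and says nothing about this swap. The expectation is therefore that the step from compound 2 to compound 3, a 1.4-fold higher number from compound 2 to compound 3 (0.14 log units; within the scatter), stays within the scatter, with no clear direction either way. In this assay compound 3 is accordingly estimated at 1500 nM, with a range from 500 nM to 4500 nM.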

Compound 3, half-maximal inhibitory concentration: 4780 nM
Compound 3: middle estimate off by 3.2-fold (0.50 log units), on the low side, and the stated range ends below it.
By their numbers in this assay, from the lowest: compound 2; then compound 3; then compound 1.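

In this assay, the place on a double-bonded chain carbon bound to a double-bonded chain carbon proves sensitive to the ring it carries: putting 4-methyl-1,3-thiazol-5-yl in place of pyridin-2-yl brings a 4.4-fold higher number from compound 2 to compound 3 (0.65 log units; beyond the scatter) even though both groups count the same number of heavy atoms. For the compounds shown here, this is the first comparison in the set that differs in one place only, and it shows that this ring swap alone, with the rest of the structure unchanged, moves the number, and that pyridin-2-yl gives the lower number of the two. No measurement on hand accounts for the size or direction of this step.

This single pair does not separate the contributions of the five-membered ring, the sulfur and the methyl group, and an unsubstituted 1,3-thiazol-5-yl or a 4-methylpyridin-2-yl at the same place would begin to pull them apart. The compounds shown also leave open whether the same swap would bring a step of similar size and direction on another core, such as that of compound 1.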